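A few compounds are considered here, and "the series" means these few. Any claim that something is new, unique, unknown or untested is made for them only; others in the source may bear on it.

Of the compounds shown here, three built on one shared core have been measured in a functional assay on CHO cells for positive allosteric modulation of metabotropic glutamate receptor 2 (Homo sapiens), with a stated time of 30 min; a lower number here means a smaller maximal response, a higher number a larger maximal response. Compound 1, `CC(C)CCn1ccc(N2CCc3ccccc3C2)c(C#N)c1=O`, carries a fused bicyclic amine on that core and gives 310%. Compound 2, `CC(C)CCn1ccc(N2CCC(c3ccccc3)CC2)c(C#N)c1=O`, carries a piperidine bearing a phenyl group and gives 268%. Compound 3, `CC(C)CCn1ccc(N2CCN(c3ccccc3)CC2)c(C#N)c1=O`, carries a piperazine bearing a phenyl group and gives 118%, which is the lowest of the three numbers: compound 2 sits nearest to it, and even that gap lies beyond the scatter, while compound 1 sits furthest away.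

The next compound is compound 4, `CC(C)CCn1ccc(N2CCN(c3ccccn3)CC2)c(C#N)c1=O`. It differs from compound 3 in one place only: pyridin-2-yl in place of phenyl on an amine nitrogen in a ring. Among the compounds with values here, none of the three measured compounds contains a pyridin-2-yl group, so there is no earlier pair that shows what this exchange does in this assay. The change is small in size, one ring atom swapped for another, and the expectation is a step from compound 3 to compound 4 of a number 7 percentage points higher from compound 3 to compound 4 (within the scatter) in this assay, that is, no shift clearly beyond the scatter. Compound 4 is therefore estimated to give 125%, within a range from 70% to 210%.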

Compound 4, largest response reached (Emax), in percent of the reference or control that the assay uses: 304%
Estimate against measurement, compound 4: 179 percentage points below; measured number above the stated range.
By their numbers in this assay, from the lowest: compound 3; then compound 2; then compounds 4 and 1 (each within the scatter of the next).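

In this assay, the exchange of phenyl for pyridin-2-yl on this amine nitrogen gives a number 186 percentage points higher from compound 3 to compound 4 (beyond the scatter), so this position responds strongly to a very small change in structure. The two groups have the same number of heavy atoms and each forms a six-membered aromatic ring, yet replacing a single ring carbon with nitrogen, which adds one hydrogen-bond acceptor to the count, is enough to produce a step of this size. Within the data shown here, this is the first pair to isolate a change at this position, and nothing available here accounts for the size of the step.

The compounds shown leave open whether the location of the ring nitrogen matters, a question that pyridin-3-yl, pyridin-4-yl or the two-nitrogen ring pyrimidin-2-yl in the same place could answer. They also leave open whether the same exchange has a similar effect elsewhere in the series, as would be tested by pyridin-2-yl in place of the phenyl group of compound 2.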